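The source may report more compounds than this note shows. Statements on the series, on what has been measured and on what is new or still open speak of the compounds shown alone.

Measured in a physicochemical assay for solubility, read by spectrophotometry, in phosphate buffer, with a stated time of 2 h, at pH 7.4; a higher number here means a more soluble compound, a lower number a less soluble compound:
compound 1 `COc1ccc2[nH]c(C(=O)N3CC(=O)N(Cc4ccccc4)[C@@H](CCc4ccccc4)C3)cc2c1` gives 4400 nM.
compound 2 `COc1ccc2[nH]c(C(=O)N3CC(=O)N(Cc4ccccc4)[C@@H](N4CCc5ccccc54)C3)cc2c1` gives 7000 nM.
compound 3 `COc1ccc2[nH]c(C(=O)N3CC(=O)N(Cc4ccccc4)[C@@H](CN4C(=O)c5ccccc5C4=O)C3)cc2c1` gives only a limit of the assay, > 100000 nM.

Compound 3 thus stands at the upper end of the numbers seen, with a limit rather than a number of its own. The two steps that reach it, an at least 22-fold higher number from compound 1 to compound 3 (1.35 log units; beyond the scatter) and an at least 14-fold higher number from compound 2 to compound 3 (1.15 log units; beyond the scatter), are both large, whereas a 1.6-fold higher number from compound 1 to compound 2 (0.20 log units; within the scatter) is not. Compound 4 `COc1ccc2[nH]c(C(=O)N3CC(=O)N(Cc4ccccc4)[C@@H](CN4[C@H](C)COC[C@@H]4C)C3)cc2c1` differs from compound 3 by a group of 8 heavy atoms (6 carbon, 1 nitrogen, 1 oxygen; one six-membered non-aromatic ring with 2 hetero atoms) in place of a group of 11 heavy atoms (8 carbon, 1 nitrogen, 2 oxygen; one five-membered non-aromatic ring with 1 hetero atom, one six-membered aromatic ring of carbon only), on a saturated chain carbon bound to a saturated ring carbon. For the measured compounds named here, no measured step covers this exchange, so the direction in this assay is open, and the starting point for compound 3 is itself only a limit. Compound 4 is expected to stay near that limit, an estimated step of a number no higher from compound 3 to compound 4 (the limit leaves the size open). The estimate for compound 4 is 100000 nM, between 25000 nM and 300000 nM.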

Compound 4, solubility: > 100000 nM
Compound 4 was reported as a limit (the forecaster's own chance of this, stated with the estimate: 55%); the middle value lies on the limit itself.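

In this assay a second, quite different group on a saturated chain carbon bound to a saturated ring carbon, 3,5-dimethylmorpholin-4-yl, also gives large steps: an at least 22-fold higher number from compound 1 to compound 4 (1.35 log units; beyond the scatter) and an at least 14-fold higher number from compound 2 to compound 4 (1.15 log units; beyond the scatter). Among these compounds, such a large step is therefore not tied to the six-membered aromatic ring of the group in compound 3, which 3,5-dimethylmorpholin-4-yl lacks. The step between compound 3 and compound 4 cannot be read, as both values are limits: the limit of > 100000 nM in this assay, at which 2 of the 4 values shown sit.

Going by these compounds, how far compound 3 and compound 4 each lie past that limit remains open. Also open, on these data alone, is whether a piperidin-1-yl group or a carboxylic acid at the same place would reach it.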